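The source may hold more compounds than are shown below. What is called first, only, known or untested is meant among the compounds shown, and "the series" means these compounds.

Compound 1 `CC1CCN(C2CCN(S(=O)(=O)c3cccc(-c4ccccc4F)c3)CC2)CC1`: in an ADME assay on HCT-116 cells (Homo sapiens) for cytotoxicity, read by CellTiter-Glo, with a stated time of 72 h (on this read-out higher numbers stand for weaker inhibition and lower numbers for stronger inhibition), compound 1 gives > 5000 nM, which is a limit of the assay rather than a number.
Compound 2 `Cc1c(C)c(S(=O)(=O)N2CCC(N3CCC(C)CC3)CC2)c(C)c2c1OC(C)(C)C2`: compound 2 gives > 10000 nM, again a limit of the assay.
Compound 3 `Cc1nc(Cl)sc1S(=O)(=O)N1CCC(N2CCC(C)CC2)CC1`: compound 3 gives > 10000 nM, also a limit of the assay.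

All three measured compounds share the same core, a piperidine bearing a second piperidine with a methyl group, linked through a sulfonyl group to a varying aromatic part. None of them reaches a measurable number. Compound 1 stands at the limit of > 5000 nM in this assay, at which 1 of the 3 values shown sits, while compound 2 and compound 3 sit at the limit of > 10000 nM in this assay, at which 2 of the 3 values shown sit. On these numbers compound 1 cannot be placed above or below the other two; all that is known is that each of them is a weak inhibitor at best.

Compound 4 `Cc1cc(C)cc(-c2cccc(S(=O)(=O)N3CCC(N4CCC(C)CC4)CC3)c2)c1` is the compound still to be measured. It differs from compound 1 in one place: 3,5-dimethylphenyl in place of 2-fluorophenyl on an aromatic carbon. Within the data shown here, since no pair of measured compounds differs in a single place, no measured step is available to lean on. Given that three different aromatic groups on the sulfonyl all leave the assay at a limit, the step from compound 1 to compound 4 is expected to stay within the scatter, with no change in either direction, so that a step that the limit leaves unreadable from compound 1 to compound 4 is the expected step. Compound 4 is accordingly estimated at 10000 nM, with an expected range from 3000 nM to 30000 nM, and most likely the assay will again report only a limit.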

Compound 4, half-maximal inhibitory concentration: > 5000 nM
Compound 4: no number, only a limit; the forecaster's own chance of this, stated with the estimate: 80%; the middle value lies beyond the limit too.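

Compound 1 and compound 4 both stop at a limit of the assay, so no step can be read from the change of 2-fluorophenyl to 3,5-dimethylphenyl: the limit of > 5000 nM in this assay, at which 2 of the 4 values shown sit. The compounds shown leave open whether any aromatic group on the shared core gives a measurable value in this assay and how far compound 1 and compound 4 truly differ.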